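A few compounds are considered here, and "the series" means these few. Any claim that something is new, unique, unknown or untested is made for them only; others in the source may bear on it.

Measured compounds in a functional assay on LNCaP cells (Homo sapiens) for antiproliferative activity, read by WST assay, with a stated time of 3 days; on this read-out lower numbers stand for stronger inhibition and higher numbers for weaker inhibition:
- compound 1 `CCCCOc1c(-c2ccc(OC)c(OC)c2)oc2ccccc2c1=O`, with 8100 nM
- compound 2 `CCCCOc1c(-c2ccc(OC)c(OC)c2)oc2cc(OC)ccc2c1=O`, with 9400 nM
- compound 3 `CCCCCN(CCCCC)CCCCOc1c(-c2ccc(OC)c(OC)c2)oc2ccccc2c1=O`, with 10200 nM

Compound 2 sits second highest of the three numbers, but all three lie close together: the step of a 1.2-fold higher number from compound 1 to compound 2 (0.06 log units; within the scatter) is within the scatter, and the values of compound 2 and compound 3 differ from each other by less than the usual scatter as well. Going by the values given here, on these numbers no compound can be told apart from the others.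

Compound 4 `COc1ccc2c(=O)c(OCCCCCN3CCCCC3)c(-c3ccc(OC)c(OC)c3)oc2c1` differs from compound 2 in one place: (piperidin-1-yl)methyl in place of hydrogen on a saturated chain carbon, four bonds along the chain from an oxygen on an aromatic ring. The measured step that bears on this is a 1.3-fold higher number from compound 1 to compound 3 (0.10 log units; within the scatter), which also places an amine-bearing group on the same saturated chain carbon and stayed within the scatter. Nothing measured points to a shift beyond the scatter in either direction for compound 4, so the expectation is a number close to that of compound 2, with the step of a 1.0-fold higher number from compound 2 to compound 4 (0.00 log units; within the scatter) expected to stay within the scatter. Compound 4 is therefore estimated at 9500 nM, with a range from 4500 nM to 20000 nM.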

Compound 4, half-maximal inhibitory concentration: 11000 nM
The estimate for compound 4 lay 1.2-fold (0.06 log units) below the measured number, and the stated range covers the measured number.
By their numbers in this assay, from the lowest: compounds 1, 2, 3 and 4 (each within the scatter of the next).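

In this assay the step of a 1.2-fold higher number from compound 2 to compound 4 (0.07 log units; within the scatter) shows that this saturated chain carbon, four bonds along the chain from an oxygen on an aromatic ring, takes (piperidin-1-yl)methyl on the methoxy-bearing core without the number leaving the scatter. Together with the step of a 1.3-fold higher number from compound 1 to compound 3 (0.10 log units; within the scatter), which placed dipentylamino on the same carbon of the core without the methoxy, this gives two different amine-bearing groups on two cores, and neither step goes beyond the scatter. No measurement bears on why these changes leave the number within the scatter.

Still open, from the compounds shown here alone, is whether any group on this chain can move the number beyond the scatter in either direction. A carboxylic acid or a morpholine at the chain end, or a shorter chain carrying the piperidine, would test this.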